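This account rests on a few compounds, and the source may have more. Where it says the series, first, only, none or still open, it means among the compounds named here.

Compound 1 `Clc1ccc(-n2cc(COc3cccc4cnc(Nc5cccc(Cl)c5)nc34)nn2)cc1` was tested in a functional assay on HCT-116 cells (Homo sapiens) for cytotoxicity, read by cell counting, with a stated time of 48 h; a lower number here means a stronger inhibitor, a higher number a weaker inhibitor. For compound 1 the result is only a limit of the assay, > 25000 nM. Compound 2 `Clc1cccc(Nc2ncc3cccc(OCc4cn(Cc5c(Cl)cccc5Cl)nn4)c3n2)c1` gives 24000 nM in this assay, and this is the only plain number shown for the pair. Within the data shown here, the step of an at least 1.0-fold lower number from compound 1 to compound 2 (0.01 log units; that floor lies within the scatter) is the one measured change on the same aromatic nitrogen, and it reaches no further than the edge of what the assay reports, (the limit of > 25000 nM in this assay, at which 1 of the 2 values shown sits). Compound 3 `Clc1cccc(Nc2ncc3cccc(OCc4cn(-c5cc(Cl)cc(Cl)c5)nn4)c3n2)c1` differs from compound 2 in one place: 3,5-dichlorophenyl in place of 2,6-dichlorobenzyl on an aromatic nitrogen. Among the measured compounds shown here, the only step on record at this position stayed within the scatter, so no step beyond the scatter is expected here either, in either direction. Compound 3 is therefore expected to give 25000 nM in this assay, with a likely range of 10000 nM to 60000 nM, a result that may again be returned only as a limit. This expectation means a step of a 1.0-fold higher number from compound 2 to compound 3 (0.02 log units; within the scatter) that is expected to stay within the scatter.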

Compound 3, half-maximal inhibitory concentration: 8000 nM
Compound 3: middle estimate off by 3.1-fold (0.49 log units), on the high side; the whole stated range lies above it.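

The step between compound 1 and compound 2 did not show a shift beyond the scatter. The group on this aromatic nitrogen can shift the read-out in this assay beyond the scatter: a 3.0-fold lower number from compound 2 to compound 3 (0.48 log units; beyond the scatter). Both groups hold two chlorines and one carbon ring, so this change cannot be pinned on the chlorine count, and it alters both the chlorine placement and the benzyl carbon. Replacing the 4-chlorophenyl gives an at least 3.1-fold lower number from compound 1 to compound 3 (0.49 log units; beyond the scatter), a size that is only a floor because compound 1 is a limit: the limit of > 25000 nM in this assay, at which 1 of the 3 values shown sits.

A 2,6-dichlorophenyl or a 3,5-dichlorobenzyl group would separate the effect of the chlorine placement from that of the extra carbon. From the compounds shown here alone, how a carboxylic acid or an amine on this aromatic ring would behave also stays open.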